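A few compounds are considered here, and "the series" means these few. Any claim that something is new, unique, unknown or untested is made for them only; others in the source may bear on it.

Measured so far in a functional assay on A549 cells (Homo sapiens) for inhibition, read by sulforhodamine B assay; on this read-out lower numbers stand for stronger inhibition of growth and higher numbers for weaker inhibition of growth:
- compound 1 `Cc1ccc2[nH]c(-c3ccc(-c4ccc(-c5cccc(Cl)c5)cc4)cc3)nc2c1` gives 2800 nM
- compound 2 `Clc1cccc(-c2ccc(-c3ccc(-c4nc5ccccc5[nH]4)cc3)cc2)c1` gives 31100 nM
- compound 3 `Oc1cccc2[nH]c(-c3ccc(-c4ccc(-c5ccc(OC(F)(F)F)cc5)cc4)cc3)nc12` gives 190 nM

Compound 1 is the second highest of these three numbers, with compound 2 nearest and compound 3 furthest, both beyond the scatter. Compound 4 `Cc1ccc2[nH]c(-c3ccc(-c4ccc(-c5ccc(F)cc5)cc4)cc3)nc2c1` keeps the core and methyl of compound 1 but has 4-fluorophenyl in place of 3-chlorophenyl on an aromatic carbon. For the measured compounds named here, the only measured step, an 11-fold higher number from compound 1 to compound 2 (1.05 log units; beyond the scatter), is large, but it concerns hydrogen in place of methyl. That methyl remains in compound 4, so this step does not bear directly on the exchange. Going by the values given here, no measured step covers the exchange itself, so no step beyond the scatter is expected in this assay, and neither direction is favoured. The expected step is a 1.1-fold lower number from compound 1 to compound 4 (0.05 log units; within the scatter) and remains an uncertain estimate. Compound 4 is estimated at 2500 nM, with 700 nM to 9000 nM as the expected range.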

Compound 4, concentration for 50% growth inhibition: 6030 nM
For compound 4 the middle estimate is 2.4-fold (0.38 log units) below the measured one; measured number inside the range.
By their numbers in this assay, from the lowest: compound 3; then compound 1; then compound 4; then compound 2.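

Working from the core of compound 1, this is the first reading on the aryl group itself rather than on the methyl: in this assay there is a 2.2-fold higher number from compound 1 to compound 4 (0.33 log units; beyond the scatter). The position is therefore not indifferent to the exchange, although the step is only modest, whereas the step for removing the methyl, an 11-fold higher number from compound 1 to compound 2 (1.05 log units; beyond the scatter), is large. The exchange alters both the halogen and its location on the ring, so this single step cannot be assigned to either change. No available data explain the direction or size of this step.

Still open, going by these compounds, is whether 4-chlorophenyl or 3-fluorophenyl would separate the halogen effect from the location effect. Also open, on these data alone, is how this position would respond to a phenyl ring bearing an amine or a carboxylic acid, and whether the same exchange behaves alike on the core of compound 3.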